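The source may report more compounds than this note shows. Statements on the series, on what has been measured and on what is new or still open speak of the compounds shown alone.

Compound 1 (`O=C(NO)c1ccc(NCCOc2ccc3cc2COC/C=C/COCc2cccc(c2)-c2ccnc(n2)N3)cc1`) gives 3840 nM
Compound 2 (`O=C(O)CCCCCCCOc1ccc2cc1COC/C=C/COCc1cccc(c1)-c1ccnc(n1)N2`) gives 27700 nM

In a functional assay on MCF7 cells (Homo sapiens) for antiproliferative activity, read by MTT assay, with a stated time of 72 h (on this read-out higher numbers stand for weaker inhibition and lower numbers for stronger inhibition), compound 2 gives the higher of the two numbers (27700 nM) and so the weaker inhibition. Compound 3 (`O=C(O)CCCCCCOc1ccc2cc1COC/C=C/COCc1cccc(c1)-c1ccnc(n1)N2`) has carboxy in place of carboxymethyl on a saturated chain carbon, six bonds along the chain from an oxygen on an aromatic ring. Among the measured compounds shown here, the only measured step (a 7.2-fold higher number from compound 1 to compound 2 (0.86 log units; beyond the scatter)) exchanged a different group. For the measured compounds named here, it was modest but beyond the scatter, and no measured step tests this change alone. A step within the scatter, with no clear direction, is therefore expected (a 1.1-fold lower number from compound 2 to compound 3 (0.04 log units; within the scatter)). Compound 3 is estimated at 25000 nM (range 11000 nM to 55000 nM).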

Compound 3, half-maximal inhibitory concentration: 20000 nM
For compound 3 the middle estimate is 1.3-fold (0.10 log units) above the measured one, and the stated range covers the measured number.
By their numbers in this assay, from the lowest: compound 1; then compounds 3 and 2 (each within the scatter of the next).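

With carboxy in place of carboxymethyl at this position, this assay shows a 1.4-fold lower number from compound 2 to compound 3 (0.14 log units; within the scatter), so this small trim of the chain gives no clear difference between these two carboxylic acids. With 4-carboxybutyl in place of (4-(hydroxycarbamoyl)phenyl)amino, the result is a 5.2-fold higher number from compound 1 to compound 3 (0.72 log units; beyond the scatter), so a second chain acid also gives weaker inhibition than compound 1. No measurement here explains either step. Still open, as far as these compounds go, is how much shorter or longer chains would give, and whether a chain ending in an amine or a methyl ester would read differently from these acids.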